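Series notes: ethoxybiphenyls, carboxy for methyl

The source may report more compounds than this note shows. Statements on the series, on what has been measured and on what is new or still open speak of the compounds shown alone.

Measured so far:
compound 1 `CCOc1ccc(-c2ccccc2)cc1` — 35%
compound 2 `CCOc1ccc(-c2cccc(C)c2)cc1` — 54%

In an assay on COS-7 cells for inhibition of patatin-like phospholipase domain-containing protein 2 (Mus musculus), tested at 200 uM (on this read-out lower numbers stand for less inhibition and higher numbers for more inhibition at the one concentration tested (going by the name of the read-out)), compound 2 stands highest of the two numbers; its nearest neighbour is compound 1, and the step of a number 19 percentage points higher from compound 1 to compound 2 (beyond the scatter) lies beyond the scatter. Compound 3 `CCOc1ccc(-c2cccc(C(=O)O)c2)cc1` differs from compound 2 by carboxy in place of methyl on an aromatic carbon. Among the measured compounds shown here, no measured step involves a carboxy group; the only measured step is methyl in place of hydrogen, so it bears on this change only indirectly. The step of a number 19 percentage points lower from compound 2 to compound 3 (beyond the scatter) is therefore an estimate with wide uncertainty, expected to go downward. Compound 3 is expected to give 35%, in the range 10% to 60%.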

Compound 3, a percentage reported as inhibition, at one concentration (the size of the read-out at that concentration, not a potency): 23%
Estimate against measurement, compound 3: 12 percentage points above; the range from low to high includes it.
By their numbers in this assay, from the lowest: compound 3; then compound 1; then compound 2.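

At this position in this assay, the direction of the change depends on the group: methyl raised the number, whereas carboxy in place of hydrogen gives a number 12 percentage points lower from compound 1 to compound 3 (beyond the scatter). Exchanging methyl for carboxy gives a number 31 percentage points lower from compound 2 to compound 3 (beyond the scatter), a large step, so this carbon distinguishes between the two groups. Nothing available accounts for this difference.

Still open, from the compounds shown here alone, is whether a methyl ester or primary amide at this carbon would stay near the carboxy value or move towards the methyl value. The compounds shown also leave open how an amine or a longer alkyl chain would behave here.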